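Two Halogen Steps Point the Way for Compound 4

The compounds below may be only part of what the source reports. "The series", "measured", "known", "first", "only" and "open" are said of these compounds alone.

Measured so far, in a functional assay on HT-29 cells (Homo sapiens) for antiproliferative activity, read by MTT assay, with a stated time of 72 h; a higher number here means a weaker inhibitor, a lower number a stronger inhibitor:
Compound 1, `CCCNC(=O)c1cc(Oc2ccc(NC(=O)c3cc4cccnc4n(-c4ccccc4)c3=O)cc2)ccn1`, gives 98 nM.
Compound 2, `CCCNC(=O)c1cc(Oc2ccc(NC(=O)c3cc4cccnc4n(-c4ccccc4F)c3=O)cc2)ccn1`, gives 200 nM.
Compound 3, `CCCNC(=O)c1cc(Oc2ccc(NC(=O)c3cc4cccnc4n(-c4ccc(Br)cc4)c3=O)cc2)ccn1`, gives 530 nM.

Compound 3 has the highest number of the three, so it is the weakest inhibitor here; its steps to compound 2 and compound 1 both lie beyond the scatter.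

Compound 4, `CCCNC(=O)c1cc(Oc2ccc(NC(=O)c3cc4cccnc4n(-c4ccc(C(F)(F)F)cc4Cl)c3=O)cc2)ccn1`, is the one still to be measured. It differs from compound 3 in one place: 2-chloro-4-(trifluoromethyl)phenyl in place of 4-bromophenyl on an aromatic nitrogen.

Among the measured compounds shown here, two measured steps bear on this change, since both put a halogen onto the same ring. The step of a 2.0-fold higher number from compound 1 to compound 2 (0.31 log units; beyond the scatter) and the step of a 5.4-fold higher number from compound 1 to compound 3 (0.73 log units; beyond the scatter) both made the number higher. Compound 4 carries two groups on that ring instead of one, so a further weakening is expected, of modest size.

For compound 4 the expected value in this assay is 1000 nM, within a range from 400 nM to 3000 nM, which means an expected step of a 1.9-fold higher number from compound 3 to compound 4 (0.28 log units; within the scatter).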

Compound 4, half-maximal inhibitory concentration: 1960 nM
For compound 4 the middle estimate is 2.0-fold (0.29 log units) below the measured one; the range from low to high includes it.
By their numbers in this assay, from the lowest: compound 1; then compound 2; then compound 3; then compound 4.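

In this assay, among the compounds shown here, the 2-chloro-4-(trifluoromethyl)phenyl group gives a higher number than any earlier group on this aromatic nitrogen, with a 3.7-fold higher number from compound 3 to compound 4 (0.57 log units; beyond the scatter) and a 9.8-fold higher number from compound 2 to compound 4 (0.99 log units; beyond the scatter) and, measured against plain phenyl, a 20-fold higher number from compound 1 to compound 4 (1.30 log units; beyond the scatter) as the only large step so far. Compound 4 is therefore the weakest inhibitor of the four, and all three substituted phenyl groups shown here give higher numbers than plain phenyl, with no compound among these four going against that pattern. No measurement shown here explains why the number rises at this position. Going by these compounds, it remains open whether a single chloro or a single trifluoromethyl on this ring would give a step of similar size, as the two appear here only together. Also open, on these data alone, is how a phenyl ring carrying an amine or a carboxylic acid, or a plain propyl chain in place of the ring, would behave at this position.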